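A few compounds are considered here, and "the series" means these few. Any claim that something is new, unique, unknown or untested is made for them only; others in the source may bear on it.

Measured in a functional assay on MGC-803 cells (Homo sapiens) for inhibition, read by MTT assay, with a stated time of 72 h; a higher number here means a weaker inhibitor, a lower number a stronger inhibitor:
- compound 1 `O=C(NCc1ccc(NC(=O)c2cc(-c3ccccc3)ccc2N2CCCC2)cc1)OCc1cccnc1` gives 10500 nM
- compound 2 `O=C(NCc1ccc(NC(=O)c2cc(F)ccc2N2CCCC2)cc1)OCc1cccnc1` gives 10700 nM
- compound 3 `COc1ccc(N2CCCC2)c(C(=O)Nc2ccc(CNC(=O)OCc3cccnc3)cc2)c1` gives 85700 nM

Compound 3 has the highest number of the three, which makes it the weakest inhibitor in this small set. Compound 1 and compound 2 sit within the scatter of each other.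

The next compound, compound 4 `O=C(NCc1ccc(NC(=O)c2cc(Cl)ccc2N2CCCC2)cc1)OCc1cccnc1`, keeps the shared core of compound 3 and changes a single group: chloro in place of methoxy on an aromatic carbon. In short, chloro takes the place of methoxy on an aromatic carbon.

Within the data shown here, no chloro compound has been measured yet, so the evidence is indirect. Two measured steps replace methoxy with another group at this place: an 8.2-fold higher number from compound 1 to compound 3 (0.91 log units; beyond the scatter) and an 8.0-fold higher number from compound 2 to compound 3 (0.90 log units; beyond the scatter). Both are modest but beyond the scatter, and both show methoxy giving the weaker inhibitor. The third step shows that phenyl and fluoro, two very different groups, give matching results: a 1.0-fold higher number from compound 1 to compound 2 (0.01 log units; within the scatter). Chloro is therefore expected to fall in with these two groups rather than with methoxy, though the set is too small to prove it.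

The expected change is a 6.6-fold lower number from compound 3 to compound 4 (0.82 log units; beyond the scatter), a step of similar size towards a stronger inhibitor. Compound 4 is estimated at 13000 nM, with an expected range from 5500 nM to 32000 nM.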

Compound 4, half-maximal inhibitory concentration: 55500 nM
Compound 4: middle estimate off by 4.3-fold (0.63 log units), on the low side, outside the stated range (above it).
By their numbers in this assay, from the lowest: compounds 1 and 2 (each within the scatter of the next); then compounds 4 and 3 (each within the scatter of the next).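

In this assay the change from methoxy to chloro on this aromatic carbon, para to the pyrrolidin-1-yl group, gives a 1.5-fold lower number from compound 3 to compound 4 (0.19 log units; within the scatter) and leaves the two groups indistinguishable at this position. Chloro instead parts from the other halogen and from phenyl, with a 5.2-fold higher number from compound 2 to compound 4 (0.71 log units; beyond the scatter) and a 5.3-fold higher number from compound 1 to compound 4 (0.72 log units; beyond the scatter), so the four compounds now form two pairs, with compound 1 and compound 2 as the stronger inhibitors and compound 3 and compound 4 as the weaker ones. The earlier compounds shown here left methoxy standing alone, whereas compound 4 shows that it has company and that two halogens need not give matching results at this position.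

As far as these compounds go, it remains open which pair a bromo group would join at this position, and whether an amine or a carboxylic acid there would fall with either pair or outside both. Nothing available on these compounds explains why chloro sides with methoxy rather than with fluoro.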